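This account rests on a few compounds, and the source may have more. Where it says the series, first, only, none or still open, it means among the compounds named here.

Three compounds have been measured in a functional assay on SW-620 cells (Homo sapiens) for inhibition, read by MTT assay, with a stated time of 72 h; a higher number here means a weaker inhibitor, a lower number a stronger inhibitor:

Compound 1, `CNCc1c(OC)cc(Oc2cccc(Nc3ccccc3)c2)cc1OC`, gives 15000 nM.
Compound 2, `COc1cc(Oc2cccc(Nc3ccccc3)c2)cc(OC)c1CNCc1ccc(C)cc1`, gives 11800 nM.
Compound 3, `COc1ccc([C@@H](C)NCc2c(OC)cc(Oc3cccc(Nc4ccccc4)c3)c(OC)c2OC)cc1`, gives 8250 nM.

Among these three numbers compound 2 stands second highest, yet its gaps to both neighbours are within the scatter, so the three compounds cannot be told apart in this assay on the numbers shown. For the measured compounds named here, the one step that can be read between them, a 1.3-fold lower number from compound 1 to compound 2 (0.10 log units; within the scatter), shows that adding a whole aromatic group on the saturated chain carbon bound to the amine nitrogen left the number essentially where it was.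

Compound 4, `COc1cc(Oc2cccc(Nc3ccccc3)c2)cc(OC)c1CNCc1ccc(O)cc1`, is the next compound to be measured. It differs from compound 2 in one place: hydroxy in place of methyl on an aromatic carbon.

Going by the values given here, no measured pair shows what hydroxy in place of methyl does here; the nearest evidence is that the aromatic group itself, in the step from compound 1 to compound 2, changed little. With the whole set lying within the scatter of one another, the expectation for compound 4 is no step beyond the scatter, in either direction, so that a 1.2-fold lower number from compound 2 to compound 4 (0.07 log units; within the scatter) is estimated as flat. The number for compound 4 is therefore expected to be about 10000 nM, within a range from 4000 nM to 30000 nM.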

Compound 4, half-maximal inhibitory concentration: 7940 nM
Beside the measured number, compound 4's estimate is 1.3-fold (0.10 log units) above it; measured number inside the range.
By their numbers in this assay, from the lowest: compounds 4, 3, 2 and 1 (each within the scatter of the next).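

Replacing methyl with hydroxy, the change from 4-methylbenzyl to 4-hydroxybenzyl, para to a large group, gives a 1.5-fold lower number from compound 2 to compound 4 (0.17 log units; within the scatter) in this assay. This swap brings in one hydrogen-bond donor and one hydrogen-bond acceptor where methyl has none, yet the step stays within the scatter, so at this position the assay does not separate the two groups. Measured against the small parent, the hydroxy-bearing aromatic group gives a 1.9-fold lower number from compound 1 to compound 4 (0.28 log units; within the scatter), which matches the methyl-bearing group in showing no step beyond the scatter, and nothing shown gives a reason for this flat result.

From the compounds shown here alone, whether a different group at the same place, such as an amine or a carboxylic acid, would move the number beyond the scatter in this assay remains open. Also open, going by these compounds, is whether any change to this aromatic group matters at all, as the four compounds, read from lowest to highest number, each sit within the scatter of the next, and none of their steps yet marks out a group that counts.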